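Swapping Methoxy for Amino on a Core Without a Number

A few compounds are considered here, and "the series" means these few. Any claim that something is new, unique, unknown or untested is made for them only; others in the source may bear on it.

Compound 3 `COc1nc(N)nc2c1c(-c1ccccc1)cn2[C@@H]1O[C@H](CO)[C@@H](O)[C@H]1O` carries a phenyl group on the shared core. In a functional assay on HL-60 cells (Homo sapiens) for antiproliferative activity, read by XTT assay, with a stated time of 72 h (on this read-out higher numbers stand for weaker inhibition and lower numbers for stronger inhibition), compound 3 gives > 20000 nM, which is a limit of the assay and not a number. Two related compounds, compound 1 `Nc1nc(N)c2c(-c3ccsc3)cn([C@@H]3O[C@H](CO)[C@@H](O)[C@H]3O)c2n1` and compound 2 `Nc1nc(N)c2c(-c3cc4ccccc4o3)cn([C@@H]3O[C@H](CO)[C@@H](O)[C@H]3O)c2n1`, carry other aromatic groups on the same core. In this assay compound 1 gives > 20000 nM, again a limit. In this assay compound 2 gives > 15000 nM, also a limit. The step that the two limits leave unreadable from compound 1 to compound 2 is therefore unreadable. Every value shown sits at a limit, as the limit of > 15000 nM in this assay, at which 1 of the 3 values shown sits, and the limit of > 20000 nM in this assay, at which 2 of the 3 values shown sit, record, so compound 3 stands level with the others, with no number to place it.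

Compound 4 `Nc1nc(N)c2c(-c3ccccc3)cn([C@@H]3O[C@H](CO)[C@@H](O)[C@H]3O)c2n1` differs from compound 3 by amino in place of methoxy on an aromatic carbon. Among the compounds with values here, no measured step concerns this exchange, and no measured step has a readable size. The expected step of a number no higher from compound 3 to compound 4 (the limit leaves the size open) is therefore none beyond the scatter. Compound 4 is expected most likely to return only a limit in this assay as well. For compound 4 the estimate in this assay is 20000 nM, with a range from 4000 nM to 100000 nM.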

Compound 4, half-maximal inhibitory concentration: > 15000 nM
Compound 4 ended at the assay's limit; the forecaster's own chance of this, stated with the estimate: 75%; the middle value is on the limit's open side.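

In this assay compound 4 gives > 15000 nM, a limit of the assay and not a number, so its steps from compound 1, compound 2 and compound 3 cannot be read. The compounds shown leave open how strongly any of the four inhibits, and whether amino or methoxy, or any of the aromatic groups, makes a difference.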